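Swapping pyridine for indole at the end of compound 1

The source may report more compounds than this note shows. Statements on the series, on what has been measured and on what is new or still open speak of the compounds shown alone.

- compound 1 `CCCSc1nc(N/N=C/c2cccnc2)c2nnn(Cc3ccccc3)c2n1` gives 58700 nM
- compound 2 `CCCSc1nc(N/N=C(\C)c2ccccc2O)c2nnn(Cc3ccccc3Cl)c2n1` gives > 64000 nM, a limit of the assay and not a number
- compound 3 `CCCSc1nc(N/N=C(\C)c2ccccc2O)c2nnn(Cc3ccc(O)cc3)c2n1` gives 9520 nM

In a functional assay on MCF7 cells (Homo sapiens) for antiproliferative activity, read by MTT assay, with a stated time of 72 h (on this read-out lower numbers stand for stronger inhibition and higher numbers for weaker inhibition), compound 1 gives 58700 nM as the higher of the two true numbers, while compound 3 gives 9520 nM as the lower one. The next compound, compound 4 `CCCSc1nc(N/N=C/c2c[nH]c3ccccc23)c2nnn(Cc3ccccc3)c2n1`, differs from compound 1 as follows: 1H-indol-3-yl in place of pyridin-3-yl on a carbon with a double bond to nitrogen. Within the data shown here, the only measured step, an at least 6.7-fold lower number from compound 2 to compound 3 (0.82 log units; beyond the scatter), changes another part of the molecule and starts from a limit. Among the measured compounds shown here, it therefore does not test this swap, and shows only that one change can move the number beyond the scatter. Compound 1 lies close to the top of the measurable range at 58700 nM, so there is more room for the number to fall than to rise. The expected change is a 2.3-fold lower number from compound 1 to compound 4 (0.37 log units; beyond the scatter), a modest drop held with little certainty. For compound 4 the estimate is 25000 nM, with the expected range running from 6000 nM to 70000 nM in this assay.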

Compound 4, half-maximal inhibitory concentration: 9010 nM
The estimate for compound 4 lay 2.8-fold (0.44 log units) above the measured number; low and high end bracket the measured number.
By their numbers in this assay, from the lowest: compounds 4 and 3 (each within the scatter of the next); then compound 1. At a limit, above all of these: compound 2.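

In this assay, the group on a carbon with a double bond to nitrogen proves able to move the number on its own: with the rest of the molecule unchanged, 1H-indol-3-yl in place of pyridin-3-yl gives a 6.5-fold lower number from compound 1 to compound 4 (0.81 log units; beyond the scatter). Among these compounds, this is the first readable step at this position, as the only earlier step changed another part of the molecule and started from a limit. The entering group has more heavy atoms and a second aromatic ring, and it trades a hydrogen-bond acceptor for a donor, so these differences arrive together in a single step.

Nothing measured here gives a reason for the lower number. On these data alone, whether the extra ring or the donor goes with that lower number stays open, and a naphthyl group in this place would bear on the question.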